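The source may hold more compounds than are shown below. What is called first, only, known or untested is meant among the compounds shown, and "the series" means these compounds.

Measured compounds: compound 1 `N#Cc1ccc(Cn2cc(COc3ccc4c(=O)ccoc4c3)nn2)cc1`, compound 2 `O=c1ccoc2cc(OCc3cn(Cc4ccc([N+](=O)[O-])cc4)nn3)ccc12`, compound 3 `Cc1ccccc1Cn1cc(COc2ccc3c(=O)ccoc3c2)nn1`.

In a functional assay on HeLa cells (Homo sapiens) for cytotoxicity, read by MTT assay, with a stated time of 48 h (on this read-out higher numbers stand for weaker inhibition and lower numbers for stronger inhibition), compound 1 gives only a limit, > 100000 nM. That limit is the limit of > 100000 nM in this assay, at which 1 of the 3 values shown sits. Compound 2 gives 25700 nM. Compound 3 gives 15300 nM, the lowest number shown, though the gap to compound 2 is within the scatter. Compound 4 `O=c1ccoc2cc(OCc3cn(Cc4ccccc4Cl)nn3)ccc12` is not yet measured. It differs from compound 3 by chloro in place of methyl on an aromatic carbon. The measured steps that change the same ring are an at least 6.5-fold lower number from compound 1 to compound 3 (0.81 log units; beyond the scatter) and a 1.7-fold lower number from compound 2 to compound 3 (0.23 log units; within the scatter); the first starts from a limit, the second lies within the scatter, and the two compounds with numbers on this ring, compound 2 and compound 3, stand within the scatter of each other. For the measured compounds named here, no measured step swaps methyl for chloro, so the change itself has no direct precedent here. For compound 4 the step is therefore expected to be a 1.0-fold lower number from compound 3 to compound 4 (0.01 log units; within the scatter), not beyond the scatter in either direction. Compound 4 is estimated at 15000 nM, between 6000 nM and 40000 nM.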

Compound 4, half-maximal inhibitory concentration: > 100000 nM
Compound 4 gave a limit, no number; the forecaster's own chance of this, stated with the estimate: 10%; middle value at least 6.6-fold (0.82 log units) away from the limit.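

In this assay, for the compounds shown here, chloro in place of methyl on the aromatic carbon ortho to a large group gives an at least 6.5-fold higher number from compound 3 to compound 4 (0.81 log units; beyond the scatter), so this single-atom exchange matters at a place where the earlier compounds offered no direct comparison. Having a group at this place therefore does not by itself secure a measurable number: 2-methylphenyl gives one, while 2-chlorophenyl gives only a limit, and the change to 2-chlorophenyl from 4-nitrophenyl gives an at least 3.8-fold higher number from compound 2 to compound 4 (0.59 log units; beyond the scatter). Compound 1 and compound 4 both give limits, so the step between them cannot be read, and both sit at the same limit: the limit of > 100000 nM in this assay, at which 2 of the 4 values shown sit.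

On these data alone, the full size of the steps to compound 4 remains open. As far as these compounds go, it is also open whether the methyl result is specific to methyl, which a fluoro, methoxy or aminomethyl group at the same place would test.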